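Ethoxy analogue of the dibrominated chromone: expected growth inhibition

The source may hold more compounds than are shown below. What is called first, only, known or untested is meant among the compounds shown, and "the series" means these compounds.

Among the compounds with values here, compound 3 `COc1ccc2c(=O)cc(C(C)Br)oc2c1CBr` holds the only number: in a functional assay on KB cells (Homo sapiens) for antiproliferative activity, read by sulforhodamine B assay, with a stated time of 72 h (a higher number here means a weaker inhibitor of growth, a lower number a stronger inhibitor of growth), compound 3 gives 15100 nM. Compound 1 `CCc1cc(=O)c2ccc(OC)c(CBr)c2o1` reaches only a limit of this assay, giving > 33600 nM. Compound 2 `CCOc1ccc2c(=O)cc(CC)oc2c1CBr` likewise reaches only a limit, giving > 32100 nM in this assay. Of the two measured steps, one is an at least 2.2-fold lower number from compound 1 to compound 3 (0.34 log units; beyond the scatter). The other, a step that the two limits leave unreadable from compound 1 to compound 2, cannot be sized because the limit of > 32100 nM in this assay, at which 1 of the 3 values shown sits, and the limit of > 33600 nM in this assay, at which 1 of the 3 values shown sits, are both limits rather than numbers.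

Compound 4 `CCOc1ccc2c(=O)cc(C(C)Br)oc2c1CBr` differs from compound 3 by methyl in place of hydrogen on a saturated chain carbon bound to an oxygen on an aromatic ring. Within the data shown here, this is the same change as the one between compound 1 and compound 2, which gives no readable size; the brominated step does not bear on it. With no readable precedent, no change beyond the scatter is expected in this assay, and the step from compound 3 to compound 4 is estimated as a 1.0-fold lower number from compound 3 to compound 4 (0.00 log units; within the scatter). Compound 4 is therefore expected at 15000 nM, with a range from 5000 nM to 45000 nM.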

Compound 4, concentration for 50% growth inhibition: 15600 nM
For compound 4 the middle estimate is 1.0-fold (0.02 log units) below the measured one, within the range that was stated.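

In this assay the methoxy to ethoxy change now reads as a 1.0-fold higher number from compound 3 to compound 4 (0.01 log units; within the scatter) on the core with the added bromo, where the earlier pair gave no size, so on this core the added methyl leaves the read-out within the scatter. The bromo in place of hydrogen on the saturated chain carbon gains a second reading as an at least 2.0-fold lower number from compound 2 to compound 4 (0.31 log units; beyond the scatter) on the ethoxy core. That change now stands on two cores, and both steps lie beyond the scatter: the same change on two cores in this assay, an at least 2.2-fold lower number (0.34 log units; beyond the scatter) from compound 1 to compound 3 and an at least 2.0-fold lower number (0.31 log units; beyond the scatter) from compound 2 to compound 4; the limit leaves it open whether they differ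

The step from compound 1 to compound 2 cannot be read, so the methoxy to ethoxy change has no size on the core without the added bromo. Whether a longer chain such as propoxy, or an amine at the end of the ethoxy chain, would stay within the scatter of compound 3 is open.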